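Thiazolyl in place of cyclobutyl on the amide carbonyl

The compounds below may be only part of what the source reports. "The series", "measured", "known", "first", "only" and "open" are said of these compounds alone.

Compound 1 `O=C(C1CCC1)N1CCCn2nc(COc3ccccc3)cc21` is measured in a functional assay on HEK293 cells for positive allosteric modulation of metabotropic glutamate receptor 5 (Homo sapiens), read by calcium flux (on this read-out lower numbers stand for smaller maximal responses and higher numbers for larger maximal responses), where compound 1 gives 41%. Compound 2 `O=C(C1CCCC1)N1CCCn2nc(COc3ccccc3)cc21` gives 41%, and compound 3 `O=C(c1ccccc1)N1CCCn2nc(COc3ccccc3)cc21` gives 63%. Compound 1 thus stands level with compound 2, the two together at the low end of the three measured numbers, and no change at the digits printed from compound 1 to compound 2 (within the scatter). Compound 3 lies furthest away: a number 22 percentage points higher from compound 1 to compound 3 (beyond the scatter), and a number 22 percentage points higher from compound 2 to compound 3 (beyond the scatter).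

The unmeasured compound 4 `O=C(c1nccs1)N1CCCn2nc(COc3ccccc3)cc21` differs from compound 1 in one place: 1,3-thiazol-2-yl in place of cyclobutyl on a carbonyl carbon.

Of the measured steps, the exchange of one saturated carbocycle for another (no change at the digits printed from compound 1 to compound 2 (within the scatter)) bears on it least; the exchange of a saturated carbocycle for a ring of another kind (a number 22 percentage points higher from compound 1 to compound 3 (beyond the scatter)) bears on it most. Among the compounds with values here, because compound 3 gives 63% while compound 1 gives 41%, a rise is expected for compound 4, though the thiazolyl has no measured precedent here, so a smaller one than for phenyl.

The step expected is a number 14 percentage points higher from compound 1 to compound 4 (beyond the scatter). Compound 4 is therefore estimated at 55%, in a range from 38% to 72%.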

Compound 4, largest response reached (reported as percent of maximum), in percent of the reference or control that the assay uses: 24%
Compound 4: middle estimate off by 31 percentage points, on the high side; measured number outside the range, below it.
By their numbers in this assay, from the lowest: compound 4; then compounds 1 and 2 (each within the scatter of the next); then compound 3.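

In this assay, within the data shown here, the group on the carbonyl carbon can move the number in either direction, whereas the earlier compounds showed only a level pair and a rise. An aromatic ring as such does not carry the gain seen with phenyl: the largest step shown is the exchange of phenyl for 1,3-thiazol-2-yl (a number 39 percentage points lower from compound 3 to compound 4 (beyond the scatter)), and the 1,3-thiazol-2-yl also lies under both saturated rings (a number 17 percentage points lower from compound 1 to compound 4 (beyond the scatter); a number 17 percentage points lower from compound 2 to compound 4 (beyond the scatter)). Nothing available here accounts for this fall.

The compounds shown leave open whether the fall goes with the ring nitrogen, the sulfur or the five-membered ring, which a thiophen-2-yl or a pyridin-2-yl on the same carbonyl would help to separate. They also leave open whether the order of these groups would hold on any core other than the shared one.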